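The source may report more compounds than this note shows. Statements on the series, on what has been measured and on what is new or still open speak of the compounds shown alone.

Measured so far:
compound 1, `CCCCCCCC/C=C\CCCCCCCC(=O)OC[C@@H](C)OP(=O)(O)OC[C@H](N)C(=O)O`: 12.4%
compound 2, `CCCCCCCC/C=C\CCCCCCCC(=O)OC[C@@H](COC)OP(=O)(O)OC[C@H](N)C(=O)O`: "not active" (no number reported)

In an assay on HEK293 cells for agonist activity at putative P2Y purinoceptor 10 (Mus musculus), with a stated time of 1 h (on this read-out higher numbers stand for larger maximal responses and lower numbers for smaller maximal responses), compound 1 gives 12.4%, a small maximal response compared with the reference. Compound 2, in this assay, is reported only as "not active" (no number reported), so no single number stands for it; it sits below compound 1 in the sense that no response worth reporting as a value was seen, but how far below cannot be said from the data at hand.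

Compound 3 is `CCCCCCCC/C=C\CCCCCCCC(=O)OC[C@@H](COCC)OP(=O)(O)OC[C@H](N)C(=O)O`. It differs from compound 2 by methyl in place of hydrogen on a saturated chain carbon bound to an oxygen on a saturated carbon. Among the compounds with values here, no step between two measured compounds is available to scale this change. Given that compound 2 already shows "not active" (no number reported), the expectation for the step in this assay from compound 2 to compound 3 is one of no change beyond the scatter, with any movement more likely to leave compound 3 without a response worth reporting than to rise toward the response of compound 1.

The maximal response of compound 3 in this assay is therefore estimated at 5%, with a range from 0% to 18%.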

Compound 3, largest response reached (Emax), in percent of the reference or control that the assay uses: "not active" (no number reported)
Compound 3: no number reported, and the estimate cannot be compared.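

In this assay, within the data shown here, compound 3, like compound 2, is reported without a number, so no step between compound 2 and compound 3 can be read. No evidence at hand bears on this result. The compounds shown leave open whether going from methoxy to ethoxy changes the maximal response by any amount.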